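Working notes: from compound 3 to compound 4

A few compounds are considered here, and "the series" means these few. Any claim that something is new, unique, unknown or untested is made for them only; others in the source may bear on it.

Measured so far in a functional assay, with a stated time of 30 min; on this read-out lower numbers stand for stronger inhibition and higher numbers for weaker inhibition
compound 1 `CC/C(C)=N\Nc1nc(-c2cccc([N+](=O)[O-])c2)cs1` gives 1180000 nM
compound 2 `C/C(CC(C)C)=N/Nc1nc(-c2cccc([N+](=O)[O-])c2)cs1` gives 1350000 nM
compound 3 `CCCC/C(C)=N\Nc1nc(-c2cccc([N+](=O)[O-])c2)cs1` gives 1180000 nM
compound 4 `CCC/C(CC)=N\Nc1nc(-c2cccc([N+](=O)[O-])c2)cs1` is not yet measured

Compound 3 gives 1180000 nM and sits within the scatter of both other measured compounds, level with compound 1 at the digits shown. Compound 4 differs from compound 3 by a group of 7 heavy atoms (6 carbon, 1 nitrogen; no ring) in place of a group of 7 heavy atoms (6 carbon, 1 nitrogen; no ring), on a nitrogen on an aromatic ring and holds the same atoms, joined differently. Among the measured compounds shown here, three measured steps bear on this, none of them the same change: a 1.1-fold higher number from compound 1 to compound 2 (0.06 log units; within the scatter), no change at the digits printed from compound 1 to compound 3 (within the scatter) and a 1.1-fold lower number from compound 2 to compound 3 (0.06 log units; within the scatter), all within the scatter. In this assay no step beyond the scatter is therefore expected, and the estimated step is a 1.0-fold higher number from compound 3 to compound 4 (0.01 log units; within the scatter) for this change. For compound 4 the expected value is 1200000 nM, with an estimated range of 700000 nM to 2000000 nM in this series.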

Compound 4, half-maximal inhibitory concentration: 1230000 nM
For compound 4 the middle estimate is 1.0-fold (0.01 log units) below the measured one, and the stated range covers the measured number.
By their numbers in this assay, from the lowest: compounds 1, 3, 4 and 2 (each within the scatter of the next).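

Exchanging one arrangement of the same atoms for another in the group on a nitrogen on an aromatic ring gives, in this assay, a 1.0-fold higher number from compound 3 to compound 4 (0.02 log units; within the scatter). The other new steps are a 1.1-fold lower number from compound 2 to compound 4 (0.04 log units; within the scatter) and a 1.0-fold higher number from compound 1 to compound 4 (0.02 log units; within the scatter), the latter with groups that differ in size. These open-chain groups therefore remain unseparated here, whether they differ in arrangement or in size.

As far as these compounds go, whether a cyclohexyl ring, an amine or a carboxylic acid in this group would give a step beyond the scatter stays open. No supporting evidence is available to explain the result.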